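This account rests on a few compounds, and the source may have more. Where it says the series, first, only, none or still open, it means among the compounds named here.

Of the compounds shown here, three have been measured. Compound 1 `ClCc1cccc(Cn2cnc3ncnc(Cl)c32)c1` gives 4070 nM in a functional assay on CAKI-1 cells (Homo sapiens) for cytotoxicity, read by sulforhodamine B assay, with a stated time of 48 h; on this read-out lower numbers stand for stronger inhibition of growth and higher numbers for weaker inhibition of growth. Compound 2 `ClCc1ccccc1Cn1cnc2ncnc(Cl)c21` gives 4160 nM in this assay. Compound 3 `ClCc1cccc(Cn2cnc3nc(Cl)nc(Cl)c32)c1` gives 3460 nM in this assay.

Compound 1 and compound 2 are built from the same atoms joined differently; the difference between the two cores is not broken down here, and their two values lie within the scatter of each other. Compound 3 differs from compound 1 by chloro in place of hydrogen on an aromatic carbon, and this gave a 1.2-fold lower number from compound 1 to compound 3 (0.07 log units; within the scatter).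

Compound 4 `ClCc1ccccc1Cn1cnc2nc(Cl)nc(Cl)c21` has not yet been measured. It differs from compound 2 by chloro in place of hydrogen on an aromatic carbon, the same change made from compound 1 to compound 3. Because the earlier step was a 1.2-fold lower number from compound 1 to compound 3 (0.07 log units; within the scatter), compound 4 is expected to show a step of a 1.2-fold lower number from compound 2 to compound 4 (0.08 log units; within the scatter) in this assay. Compound 4 is therefore estimated at 3500 nM, most likely between 1800 nM and 7000 nM.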

Compound 4, concentration for total growth inhibition: 34700 nM
The estimate for compound 4 lay 9.9-fold (1.00 log units) below the measured number; the whole stated range lies below it.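

Chloro in place of hydrogen on an aromatic carbon, between two ring nitrogen atoms, gave an 8.3-fold higher number from compound 2 to compound 4 (0.92 log units; beyond the scatter) in this assay, a weakening of growth inhibition on the core of compound 2. The same change therefore did not carry from one core to the other, and its outcome here depended on the core that received it: the same change on two cores in this assay, a 1.2-fold lower number (0.07 log units; within the scatter) from compound 1 to compound 3 and an 8.3-fold higher number (0.92 log units; beyond the scatter) from compound 2 to compound 4, 9.8-fold (0.99 log units) apart, beyond the scatter of two such steps. Going by these compounds alone, this rests on only two pairs of compounds, so it shows that the step cannot be assumed to transfer, but it does not show what in the two cores sets them apart.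

The compounds shown leave open how an amine or a methoxy group at that same aromatic carbon would behave on either core. They also leave open whether such groups would separate the two cores as chloro does.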